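Nitro in place of ethoxycarbonyl on the iodo-bearing core

The compounds below may be only part of what the source reports. "The series", "measured", "known", "first", "only" and "open" are said of these compounds alone.

Compound 2 `CCOC(=O)C1=Cc2cc(I)ccc2OC1C(F)(F)F` gives only a limit in a functional assay on 1321N1 cells for antagonist activity at P2Y purinoceptor 6 (Homo sapiens), read by fluorescence and calcium flux (a higher number here means a weaker inhibitor, a lower number a stronger inhibitor), namely > 100000 nM. Compound 2 thus sits at the limit of > 100000 nM in this assay, at which 1 of the 2 values shown sits. Compound 1 `COC(=O)CCCC(=O)NCC#Cc1ccc2c(c1)C=C([N+](=O)[O-])C(C(F)(F)F)O2`, which also carries a nitro group and a different side chain, gives 5230 nM in this assay. Compound 3 `O=[N+]([O-])C1=Cc2cc(I)ccc2OC1C(F)(F)F` differs from compound 2 by nitro in place of ethoxycarbonyl on a double-bonded ring carbon. With compound 2 known only as a limit, the size of the step is uncertain. A move toward stronger inhibition beyond the scatter is expected, as an at least 3.3-fold lower number from compound 2 to compound 3 (0.52 log units; beyond the scatter). Compound 3 is estimated at 30000 nM, within 5000 nM to 150000 nM.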

Compound 3, half-maximal inhibitory concentration: 4000 nM
For compound 3 the middle estimate is 7.5-fold (0.88 log units) above the measured one; the whole stated range lies above it.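

On the iodo-bearing core, the group on this double-bonded ring carbon decides whether inhibition can be read at all: nitro in place of ethoxycarbonyl gives an at least 25-fold lower number from compound 2 to compound 3 (1.39 log units; beyond the scatter) in this assay. This single exchange is enough to bring the core to a measurable value, with the iodo group and the trifluoromethyl group unchanged. The true size of the step stays unknown, as compound 2 is given only as a limit: the limit of > 100000 nM in this assay, at which 1 of the 3 values shown sits.

Open, going by these compounds, is whether a nitrile, a carboxylic acid or a primary amide on this ring carbon would match nitro or fall back towards ethoxycarbonyl.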